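A few compounds are considered here, and "the series" means these few. Any claim that something is new, unique, unknown or untested is made for them only; others in the source may bear on it.

Measured compounds:
Compound 1, `C/C(=N\c1nc2ccc(OC(F)(F)F)cc2s1)N(C)C`: in a functional assay on Cortex (Rattus norvegicus, strain Sprague-Dawley) (a higher number here means that more compound is needed for the effect, a lower number that less compound is needed), compound 1 gives 0.1 uM.
Compound 2, `CCNC(=S)Nc1nc2ccc(OC(F)(F)F)cc2s1`: in this assay compound 2 gives 1 uM.

Within the data shown here, compound 2 stands at the highest of the two numbers measured so far; its nearest neighbour is compound 1, separated from it by the single step known, a 10-fold higher number from compound 1 to compound 2 (1.00 log units; beyond the scatter). That step replaces one group with another on an aromatic carbon of the shared core and is a change of a different kind from the one now in question.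

Compound 3, `CCCNC(=S)Nc1nc2ccc(OC(F)(F)F)cc2s1`, has not yet been measured. It differs from compound 2 by methyl in place of hydrogen on a saturated chain carbon, two bonds along the chain from an amide-type nitrogen. Among the measured compounds shown here, no measured pair of compounds differs in this way, so nothing among the measured steps bears directly on it. In that situation the sensible expectation for this assay is no movement beyond the scatter in either direction. Compound 3 is therefore expected to give about 1 uM, within a range from 0.3 uM to 3 uM. That estimate means an expected step of no change at the digits printed from compound 2 to compound 3 (within the scatter).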

Compound 3, minimum effective concentration: 0.01 uM
Beside the measured number, compound 3's estimate is 100-fold (2.00 log units) above it; measured number below the stated range.
By their numbers in this assay, from the lowest: compound 3; then compound 1; then compound 2.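

In this assay, methyl in place of hydrogen on a saturated chain carbon, two bonds along the chain from an amide-type nitrogen, which turns ethylamino into propylamino, proves a highly sensitive change, with a 100-fold lower number from compound 2 to compound 3 (2.00 log units; beyond the scatter). The earlier compounds had shown this kind of group only as the poorer one against the group carried by compound 1, with a 10-fold higher number from compound 1 to compound 2 (1.00 log units; beyond the scatter), whereas the propylamino version reverses that order, with a 10-fold lower number from compound 1 to compound 3 (1.00 log units; beyond the scatter); among these three compounds, the direction of the difference from compound 1 therefore depends on the chain difference of ethylamino and propylamino. Nothing available speaks to what lies behind this large step.

The compounds shown leave open whether the trend continues, levels off or turns back with a longer chain such as butyl, or how a branched chain such as isopropyl or a ring such as cyclopropyl would compare at the same place. They also leave open whether ethyl to propyl would have a similar effect on the shared core if the trifluoromethoxy group gave way to another group, such as chlorine or methoxy.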